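The source may report more compounds than this note shows. Statements on the series, on what has been measured and on what is new or still open speak of the compounds shown alone.

Series notes. Compound 1 `CC(=O)c1ccc2c(c1)nc(-c1ccoc1)n2C1CCCCC1` carries an acetyl group on the shared core; compound 2 `CC(=O)c1ccc2c(c1)nc(-c1ccccn1)n2C1CCCCC1` and compound 3 `C/C(=N\NC(N)=S)c1ccc2c(c1)nc(-c1ccoc1)n2C1CCCCC1` each alter one group of it, and compound 4 `C/C(=N\NC(N)=S)c1ccc2c(c1)nc(-c1ccccn1)n2C1CCCCC1` remains to be measured. In an ADME assay on MDBK cells (Bos taurus) for cytotoxicity, read by MTT assay, with a stated time of 96 h (on this read-out lower numbers stand for higher toxicity in this test and higher numbers for lower toxicity in this test), compound 1 reaches only a limit, > 100000 nM. In this assay compound 2 likewise stops at a limit, > 100000 nM. In this assay compound 3 again yields only a limit, > 100000 nM. The change pyridin-2-yl in place of furan-3-yl on an aromatic carbon gave a step that the two limits leave unreadable from compound 1 to compound 2. The cores of compound 3 and compound 1 differ by a group of 7 heavy atoms (3 carbon, 3 nitrogen, 1 sulfur; no ring) in place of a group of 3 heavy atoms (2 carbon, 1 oxygen; no ring), on an aromatic carbon, with a step that the two limits leave unreadable from compound 1 to compound 3. The same change, (pyridin-2-yl in place of furan-3-yl on an aromatic carbon), is now applied to the core of compound 3. Since every value shown rests at the limit of > 100000 nM in this assay, at which 3 of the 3 values shown sit, the step is expected to be a number no higher from compound 3 to compound 4 (the limit leaves the size open), unresolvable within these bounds. Compound 4 is therefore expected to give 100000 nM, most probably reported as a limit only.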

Compound 4, half-maximal cytotoxic concentration: 41000 nM
For compound 4 the middle estimate is 2.4-fold (0.39 log units) above the measured one; measured number outside the range, below it.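

In this assay, pyridin-2-yl in place of furan-3-yl on the core of compound 3 gives an at least 2.4-fold lower number from compound 3 to compound 4 (0.38 log units; beyond the scatter), and the group of 7 heavy atoms in place of the acetyl group on the pyridin-2-yl core gives an at least 2.4-fold lower number from compound 2 to compound 4 (0.38 log units; beyond the scatter). Only the combination of both changes, in compound 4, gives a measurable number, so both steps are minimum sizes. The remaining steps cannot be read, so the change is not shown to have the same or a different size on the acetyl core: the limit of > 100000 nM in this assay, at which 3 of the 4 values shown sit.

Going by these compounds, it remains open whether a phenyl ring or a pyridin-3-yl group in place of pyridin-2-yl would also give a measurable number in this assay when the group of 7 heavy atoms is present. The same question stands for an amine or a carboxylic acid in place of that group.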